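The compounds below may be only part of what the source reports. "The series", "measured", "known", "first", "only" and "open" are said of these compounds alone.

Working notes on the series. Three compounds have numbers in a functional assay on cells (Cancer cell lines, Homo sapiens) for cytotoxicity, with a stated time of 48 h; a higher number here means a weaker inhibitor of growth, a lower number a stronger inhibitor of growth. Compound 1 `COc1ccc2c(c1)/C(=C\c1c(Cl)n(Cc3cc(OC)c(OC)c(OC)c3)c3cc(C)c(OC)cc13)C(=O)N2` gives 75900 nM in this assay. Compound 2 `COc1ccc2c(c1)/C(=C\c1c(OC)n(-c3ccccc3)c3ccccc13)C(=O)N2` gives 9550 nM. Compound 3 `O=C1Nc2ccc(Cl)cc2/C1=C\c1c(Cl)n(CCCc2ccccc2)c2ccccc12` gives 10200 nM.

Compound 3 stands second highest of the three. Its nearest neighbour is compound 2, whose number lies within the scatter of repeated measurements, so no order can be read between compounds 2 and 3. Its furthest neighbour is compound 1, whose number lies beyond the scatter on the higher side, so compound 3 is the stronger growth inhibitor of that pair. For the measured compounds named here, none of the three differ from each other in a single place, so no single-change step has been measured yet.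

Compound 4 `O=C1Nc2ccccc2/C1=C\c1c(Cl)n(CCCc2ccccc2)c2ccccc12` is not yet measured in this assay. It differs from compound 3 in one place: hydrogen in place of chloro on an aromatic carbon. Nothing in the measured set shows what such a change does to the number. Absent any measured step of this kind, compound 4 is expected to stay close to compound 3, with the step of a 1.2-fold higher number from compound 3 to compound 4 (0.07 log units; within the scatter) not expected to exceed the scatter. The estimate for compound 4 is 12000 nM, with a range from 4000 nM to 40000 nM.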

Compound 4, concentration for total growth inhibition: 75900 nM
Compound 4: the middle estimate sits 6.3-fold (0.80 log units) below what was measured; measured number above the stated range.
By their numbers in this assay, from the lowest: compounds 2 and 3 (each within the scatter of the next); then compounds 1 and 4 (each within the scatter of the next).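

For the compounds shown here, the first single-change step falls at this position: in this assay, hydrogen in place of chloro on an aromatic carbon gives a 7.4-fold higher number from compound 3 to compound 4 (0.87 log units; beyond the scatter), a step beyond the scatter. The chloro on this six-membered aromatic ring of carbon only, meta to a fused ring and para to a fused ring, therefore matters to the number within this pair, and compound 3, which carries it, is the stronger growth inhibitor of the two. No measurement at hand accounts for the size of this step.

The compounds shown leave open whether another group on this aromatic carbon, such as fluoro, an amine or a carboxylic acid, would stay with compound 3 or fall with compound 4. They also leave open whether the loss of the chloro costs the same with other groups elsewhere on the shared core, since compound 1 and compound 2 each differ from this pair in more than one place and offer no comparison.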